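Trifluoromethyl and fluorine on the amide aryl ring

The source may report more compounds than this note shows. Statements on the series, on what has been measured and on what is new or still open speak of the compounds shown alone.

Three compounds share one core, a bicyclic ring carrying a piperazine whose far nitrogen bears an acetamide linked to an aromatic ring. Compound 1 `O=C(CN1CCN(c2nnc(Cc3ccncc3)c3ccccc23)CC1)Nc1cccc(F)c1` carries a pyridylmethyl arm on the core; in a functional assay on HT-29 cells (Homo sapiens) for cytotoxicity, read by MTT assay, with a stated time of 72 h (a higher number here means a weaker inhibitor, a lower number a stronger inhibitor), compound 1 gives 6130 nM. Compound 2 `O=C(CN1CCN(c2nnc(Cc3ccccc3)c3ccccc23)CC1)Nc1ccc(F)c(Cl)c1` and compound 3 `O=C(CN1CCN(c2nnc(Cc3ccccc3)c3ccccc23)CC1)Nc1cccc(Br)c1` carry a benzyl arm instead and differ only in the aromatic ring on the amide nitrogen: compound 2 gives 13300 nM and compound 3 gives 13400 nM. Compound 1 thus gives the lowest number of the three, and both other compounds lie beyond the scatter from it.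

Compound 4 `O=C(CN1CCN(c2nnc(Cc3ccncc3)c3ccccc23)CC1)Nc1ccc(F)c(C(F)(F)F)c1` keeps the pyridylmethyl arm of compound 1 and changes only the amide aryl ring: 4-fluoro-3-(trifluoromethyl)phenyl in place of 3-fluorophenyl on an amide-type nitrogen.

For the measured compounds named here, the one measured step that touches the same part of the molecule is a 1.0-fold higher number from compound 2 to compound 3 (0.00 log units; within the scatter), a swap of substituents on the amide aryl ring that left the number unchanged. On that basis the change from compound 1 to compound 4 is expected to move the number little, with an estimated step of a 1.1-fold higher number from compound 1 to compound 4 (0.03 log units; within the scatter). Compound 4 is therefore estimated at 6500 nM, with a range from 2500 nM to 16000 nM.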

Compound 4, half-maximal inhibitory concentration: 1110 nM
Beside the measured number, compound 4's estimate is 5.9-fold (0.77 log units) above it; measured number below the stated range.
By their numbers in this assay, from the lowest: compound 4; then compound 1; then compounds 2 and 3 (each within the scatter of the next).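

In this assay, the aromatic ring on the amide nitrogen proves able to move the number well beyond the scatter. With the pyridylmethyl arm held fixed, placing 4-fluoro-3-(trifluoromethyl)phenyl where 3-fluorophenyl stood gives a 5.5-fold lower number from compound 1 to compound 4 (0.74 log units; beyond the scatter). For the compounds shown here, the only earlier change on this ring, a 1.0-fold higher number from compound 2 to compound 3 (0.00 log units; within the scatter), was made with a benzyl arm on the core and left the number flat, so a flat result for one swap on this ring does not carry over to another. No measurement at hand explains the size of the new step.

The compounds shown leave open how much of the step belongs to the trifluoromethyl group and how much to the fluorine, and whether a nitrile or a methoxy group on this ring would give a similar number. They also leave open whether the 4-fluoro-3-(trifluoromethyl)phenyl ring would lower the number in the same way with a benzyl arm on the core.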